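A 2-hydroxyethyl group added to compound 3

This account rests on a few compounds, and the source may have more. Where it says the series, first, only, none or still open, it means among the compounds named here.

Compound 1 `COc1cc2c(Nc3ccc(C#N)cc3)ncnc2cc1OCCCN(C)C`: 34900 nM
Compound 2 `COc1cc2c(Nc3ccc(C#N)cc3)ncnc2cc1OCCCN(C)Cc1ccccc1`: > 100000 nM
Compound 3 `COc1cc2c(Nc3ccc(C#N)cc3)ncnc2cc1OCCCN1CCCCC1`: 18800 nM

All three compounds were tested in a functional assay on SH-SY5Y cells (Homo sapiens) for antiproliferative activity, read by MTT assay, with a stated time of 72 h; on this read-out higher numbers stand for weaker inhibition and lower numbers for stronger inhibition. For compound 2, the entry > 100000 nM is a limit and not a number.

Only compound 1 and compound 3 have true numbers, and a 1.9-fold lower number from compound 1 to compound 3 (0.27 log units; within the scatter) lies within the scatter, so the two cannot be told apart. The gap to the limit is clearer: an at least 5.3-fold lower number from compound 2 to compound 3 (0.72 log units; beyond the scatter) lies beyond the scatter.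

Compound 4 `COc1cc2c(Nc3ccc(C#N)cc3)ncnc2cc1OCCCN1CCCCC1CCO` carries one change: 2-hydroxyethyl in place of hydrogen on a saturated ring carbon. This turns piperidin-1-yl into 2-(2-hydroxyethyl)piperidin-1-yl, with the new group next to the ring nitrogen.

Going by the values given here, no measured step makes this exact change. The closest guides are changes to the same amine: the swap to piperidin-1-yl gave a 1.9-fold lower number from compound 1 to compound 3 (0.27 log units; within the scatter), whereas adding phenyl gave an at least 2.8-fold higher number from compound 1 to compound 2 (0.45 log units; beyond the scatter). A modest shift toward a higher number is therefore expected in this assay, and it may stay within the scatter. The expected step is a 1.6-fold higher number from compound 3 to compound 4 (0.20 log units; within the scatter). Compound 4 is estimated at 30000 nM, with an expected range of 10000 nM to 90000 nM.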

Compound 4, half-maximal inhibitory concentration: > 100000 nM
Compound 4 ended at the assay's limit; the forecaster's own chance of this, stated with the estimate: 15%; middle value at least 3.3-fold (0.52 log units) away from the limit.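

On a saturated ring carbon next to the ring nitrogen, 2-hydroxyethyl clearly weakens inhibition in this assay, with an at least 5.3-fold higher number from compound 3 to compound 4 (0.72 log units; beyond the scatter). Going by these compounds alone, the earlier compounds changed only the whole amine, so this is the first sign that a group on the piperidine ring itself matters. The new amine also separates from dimethylamino, with an at least 2.8-fold higher number from compound 1 to compound 4 (0.45 log units; beyond the scatter), although compound 1 and compound 3 could not be told apart. The value of compound 4 is a limit and not a number, and its step to compound 2 cannot be read, since both compounds rest on a limit: the limit of > 100000 nM in this assay, at which 2 of the 4 values shown sit.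

From the compounds shown here alone, the true size of the loss stays open. So does whether it follows the hydroxyl or the carbon chain, which an ethyl or 2-methoxyethyl group on the same ring carbon would help to separate.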